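This account rests on a few compounds, and the source may have more. Where it says the series, first, only, none or still open, it means among the compounds named here.

Measured compounds:
compound 1 `Cc1nn(C)c2nc(C3CC3)c(/C=C/[C@@H](O)C[C@@H](O)CC(=O)O)c(-c3ccc(F)cc3)c12` — 74.3%
compound 2 `CC(C)c1nc2c(c(-c3ccccc3)nn2C)c(-c2ccc(F)cc2)c1/C=C/[C@@H](O)C[C@@H](O)CC(=O)O` — 71.1%

In an in vivo functional assay on the whole organism for inhibition of 3-hydroxy-3-methylglutaryl-coenzyme A reductase (Rattus norvegicus), at a dose of 2 mg/kg by the oral route (a lower number here means a weaker effect, a higher number a stronger effect of the compound at the dose given), compound 1 gives 74.3% and compound 2 gives 71.1%. Compound 2 is the nearer neighbour of compound 1 on these two numbers, and the gap between the two lies within the usual scatter, so the pair is read as level and no order between them can be claimed.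

Compound 3 `Cn1nc(-c2ccccc2)c2c(-c3ccc(F)cc3)c(/C=C/[C@@H](O)C[C@@H](O)CC(=O)O)c(C3CC3)nc21` has not been measured. It differs from compound 2 in one place: cyclopropyl in place of isopropyl on an aromatic carbon. Going by the values given here, no step between measured compounds isolates this exchange; compound 1 does carry cyclopropyl at that aromatic carbon, but it also differs from compound 2 elsewhere, so its level value with compound 2 only shows that a cyclopropyl-bearing member of the series can reach the same range. With nothing beyond that, the step from compound 2 to compound 3 is expected to stay within the scatter: a number 1.9 percentage points higher from compound 2 to compound 3 (within the scatter), in no firm direction. Compound 3 is therefore estimated at 73%, with a range of 60% to 84%.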

Compound 3, a percentage reported as inhibition, in the whole organism at one dose (the size of the read-out at that dose, not a potency): 11.5%
Compound 3: the middle estimate sits 61.5 percentage points above what was measured; the whole stated range lies above it.
By their numbers in this assay, from the lowest: compound 3; then compounds 2 and 1 (each within the scatter of the next).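

In this assay, cyclopropyl in place of isopropyl on the aromatic carbon next to the ring nitrogen gives a number 59.6 percentage points lower from compound 2 to compound 3 (beyond the scatter), so this position is far less forgiving than the level pair of compound 1 and compound 2 suggested, even though the two groups have the same heavy-atom count. Phenyl in place of methyl on the other aromatic carbon, with cyclopropyl held fixed, gives a number 62.8 percentage points lower from compound 1 to compound 3 (beyond the scatter), so cyclopropyl is compatible with high inhibition alongside methyl and phenyl is compatible with it alongside isopropyl, and within these three compounds the loss appears only where cyclopropyl and phenyl occur together. Nothing here gives a measured property that would account for this dependence of one position on the other.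

The fourth combination, isopropyl with methyl, stands outside the compounds shown, so the size of each exchange on that background remains open. Going by these compounds, it also remains open whether ethyl or tert-butyl at the carbon next to the ring nitrogen, or a methoxy group in place of phenyl, would keep inhibition at the single oral dose.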